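A Hydroxyphenyl to Chlorophenyl Swap on a Pyrazolyl Core

The source may hold more compounds than are shown below. What is called first, only, known or untested is meant among the compounds shown, and "the series" means these compounds.

Of the compounds shown here, three have been measured in a functional assay, with a stated time of 150 min; a higher number here means a weaker inhibitor, a lower number a stronger inhibitor. Compound 1 `COc1ccc(-c2nc(SC)n(C)c(=O)c2C#N)cc1` gives 73 ug/mL, compound 2 `CCOC(=O)c1cnn(-c2nc(-c3ccccc3O)c(C#N)c(=O)n2C)c1N` gives 64 ug/mL, and compound 3 `CSc1nc(-c2ccccc2Cl)c(C#N)c(=O)n1C` gives 81 ug/mL. Compound 2 carries the lowest of the three numbers, but both of the others lie within the scatter of it, so no order among them can be claimed. Compound 4 `CCOC(=O)c1cnn(-c2nc(-c3ccc(Cl)cc3)c(C#N)c(=O)n2C)c1N` has not yet been measured in this assay. It differs from compound 2 in one place: 4-chlorophenyl in place of 2-hydroxyphenyl on an aromatic carbon. Within the data shown here, with no comparable step among the measured compounds to draw on, and all three numbers sitting close together, the step from compound 2 to compound 4 is expected to be a 1.2-fold higher number from compound 2 to compound 4 (0.07 log units; within the scatter), that is, none beyond the scatter in either direction. Compound 4 is therefore estimated at 75 ug/mL, in a range from 40 ug/mL to 140 ug/mL.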

Compound 4, half-maximal inhibitory concentration: 87 ug/mL
Compound 4: the middle estimate sits 1.2-fold (0.06 log units) below what was measured; measured number inside the range.
By their numbers in this assay, from the lowest: compounds 2, 1, 3 and 4 (each within the scatter of the next).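

In this assay, among these compounds, 4-chlorophenyl in place of 2-hydroxyphenyl on this aromatic carbon gives a 1.4-fold higher number from compound 2 to compound 4 (0.13 log units; within the scatter) and is the first step that can be read at this position. Losing the hydrogen-bond donor and acceptor counted on the 2-hydroxyphenyl group therefore goes with no change beyond the scatter here. Nothing measured bears on why this is so. Because this single step changes both the substituent and its place on the phenyl ring, the two cannot be separated. Going by these compounds, whether an amine or a carboxylic acid on that ring would shift the number remains open.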